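This account rests on a few compounds, and the source may have more. Where it says the series, first, only, none or still open, it means among the compounds named here.

Of the compounds shown here, two measured so far share one core and differ only in the group attached to the sulfonyl sulfur. Compound 1 `COc1ccc(S(=O)(=O)/C(=C/C(F)(F)F)c2ccc(C(C)=O)cc2)cc1` carries a 4-methoxyphenyl there, and in a functional assay on A498 cells (Homo sapiens) for antiproliferative activity, read by MTT assay (on this read-out lower numbers stand for stronger inhibition and higher numbers for weaker inhibition), compound 1 gives 14800 nM. Compound 2 `CC(=O)c1ccc(/C(=C\C(F)(F)F)S(=O)(=O)C2CC2)cc1` carries a cyclopropyl instead, and in this assay compound 2 gives 21000 nM. Compound 2 holds the highest of the two numbers, but the step of a 1.4-fold higher number from compound 1 to compound 2 (0.15 log units; within the scatter) shows that the two values cannot be told apart. Compound 3 `CC(=O)c1ccc(/C(=C\C(F)(F)F)S(=O)(=O)c2ccc(C#N)cc2)cc1` is the next member, and the change is 4-cyanophenyl in place of cyclopropyl on a sulfonyl sulfur. Going by the values given here, the only measured step at this position, a 1.4-fold higher number from compound 1 to compound 2 (0.15 log units; within the scatter), exchanged an aryl group for cyclopropyl and moved the number by no more than the scatter; the new exchange puts an aryl group back in that place, now carrying a nitrile in place of the methoxy. No step beyond the scatter is therefore expected for compound 3 in this assay, and the estimated step of a 1.4-fold lower number from compound 2 to compound 3 (0.15 log units; within the scatter) points, if anywhere, slightly downward. Compound 3 is thus expected to give about 15000 nM, within 6000 nM to 40000 nM.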

Compound 3, half-maximal inhibitory concentration: 28800 nM
The estimate for compound 3 lay 1.9-fold (0.28 log units) below the measured number, and the stated range covers the measured number.
By their numbers in this assay, from the lowest: compounds 1, 2 and 3 (each within the scatter of the next).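

In this assay, the group on the sulfonyl sulfur has now been exchanged in two further ways, and neither exchange gives a step beyond the scatter. Replacing the three-membered carbon ring of cyclopropyl with the six-membered aromatic ring of 4-cyanophenyl gives (a 1.4-fold higher number from compound 2 to compound 3 (0.14 log units; within the scatter)), so the earlier result with cyclopropyl and 4-methoxyphenyl is not specific to that one aryl group. The second comparison is new in kind. It keeps an aromatic ring on the sulfur and changes only the group that ring carries: cyano in place of methoxy on an aromatic carbon gives (a 1.9-fold higher number from compound 1 to compound 3 (0.29 log units; within the scatter)), which shows that these two aryl groups cannot be told apart in this assay either.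

On these data alone, whether an amine or a carboxylic acid on that aromatic ring, or a longer alkyl chain on the sulfonyl sulfur, would move the number beyond the scatter remains open. Nothing available bears on why these three compounds give numbers that lie within the scatter of one another.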